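The source may hold more compounds than are shown below. What is called first, only, known or untested is meant among the compounds shown, and "the series" means these compounds.

Measured compounds:
compound 1, `C/C(=N\NC(N)=S)c1ccc2[nH]c(-c3ccc(Cl)cc3)nc2c1`, > 100000 nM
compound 2, `C/C(=N\NC(N)=S)c1ccc2[nH]c(-c3ccc(C(F)(F)F)cc3)nc2c1`, 22000 nM
compound 3, `CC(=O)c1ccc2c(c1)nc(-c1ccc(Cl)cc1)n2C1CCCCC1`, > 100000 nM

All three were tested in an ADME assay on Vero cells (Chlorocebus sabaeus) for cytotoxicity, read by MTT assay, with a stated time of 96 h; a lower number here means that less compound is tolerated, a higher number that more compound is tolerated. For compound 1 the result is only a limit of the assay, > 100000 nM. Compound 2 gives a number, 22000 nM, and the difference between the two is an at least 4.5-fold lower number from compound 1 to compound 2 (0.65 log units; beyond the scatter). Going by the values given here, the only change between them is trifluoromethyl in place of chloro on an aromatic carbon. Compound 3, which is built on a different core, also reaches only a limit, > 100000 nM; how its core differs from that of compound 1 is not broken down here. Two of the three values rest at the same point, (the limit of > 100000 nM in this assay, at which 2 of the 3 values shown sit).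

Compound 4, `CC(=O)c1ccc2c(c1)nc(-c1ccc(C(F)(F)F)cc1)n2C1CCCCC1`, has not yet been tested. It differs from compound 3 by trifluoromethyl in place of chloro on an aromatic carbon, and the surroundings of the change are described in the same words as for the change from compound 1 to compound 2, so this is the same change on a second core. Among the compounds with values here, the single measured example of it shows a lower number for compound 2, an at least 4.5-fold lower number from compound 1 to compound 2 (0.65 log units; beyond the scatter), and on that the expectation for compound 4 rests. The step from compound 3 to compound 4 is estimated as an at least 3.3-fold lower number from compound 3 to compound 4 (0.52 log units; beyond the scatter) in this assay. Compound 4 is expected to give about 30000 nM, likely between 8000 nM and 100000 nM, with a real chance that this assay again reports only a limit.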

Compound 4, half-maximal cytotoxic concentration: 35000 nM
Beside the measured number, compound 4's estimate is 1.2-fold (0.07 log units) below it; low and high end bracket the measured number.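

In this assay, putting trifluoromethyl in place of chloro on the core of compound 3 gives an at least 2.8-fold lower number from compound 3 to compound 4 (0.45 log units; beyond the scatter), which points the same way as the step on the core of compound 1, so in both measured pairs the cells tolerate less of the trifluoromethyl compound. This shows that the direction of the change carried over from one core to the other, but it does not show that the size carried over, as the two steps set side by side make plain: the same change on two cores in this assay, an at least 4.5-fold lower number (0.65 log units; beyond the scatter) from compound 1 to compound 2 and an at least 2.8-fold lower number (0.45 log units; beyond the scatter) from compound 3 to compound 4; the limit leaves it open whether they differ Each step starts from a compound that reaches only a limit of the assay, so the true size of either step remains unknown, and two cores cannot establish a rule for the whole series: the limit of > 100000 nM in this assay, at which 2 of the 4 values shown sit.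

As far as these compounds go, only chloro and trifluoromethyl appear at this place on the ring, so it remains open whether a different group there, such as a methyl, a nitrile, an amine or a carboxylic acid, would be tolerated better or worse by the cells. From the compounds shown here alone, it also remains open whether the same step would appear on a third core, or with a different kind of cell.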